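A Piperidine Amide Returns in Place of the Chain

The source may report more compounds than this note shows. Statements on the series, on what has been measured and on what is new or still open speak of the compounds shown alone.

Compound 3 `Cc1nc(NCCNS(C)(=O)=O)nc2ccc(NC(=O)/C=C/c3ccc(OC(F)(F)F)cc3)cc12` gives 169 nM in an assay on CHO-K1 cells for displacement of a labelled ligand from melanin-concentrating hormone receptor 1 (Homo sapiens), read by scintillation proximity assay, with a stated time of 2 h (on this read-out lower numbers stand for stronger inhibition and higher numbers for weaker inhibition), the highest of the three numbers seen. Compound 1 `COCC(=O)NC1CCN(c2nc(C)c3cc(NC(=O)/C=C/c4ccc(OC(F)(F)F)cc4)ccc3n2)CC1` gives 32 nM and compound 2 `Cc1nc(NCCCNS(C)(=O)=O)nc2ccc(NC(=O)/C=C/c3ccc(OC(F)(F)F)cc3)cc12` gives 54 nM; the steps among them were a 5.3-fold higher number from compound 1 to compound 3 (0.72 log units; beyond the scatter), a 3.1-fold higher number from compound 2 to compound 3 (0.50 log units; beyond the scatter) and a 1.7-fold higher number from compound 1 to compound 2 (0.23 log units; within the scatter). Compound 4 `Cc1nc(N2CCC(N3CCCC3=O)CC2)nc2ccc(NC(=O)/C=C/c3ccc(OC(F)(F)F)cc3)cc12` carries 4-(2-oxopyrrolidin-1-yl)piperidin-1-yl in place of (2-(methanesulfonamido)ethyl)amino on an aromatic carbon. The step that bears on this change is a 5.3-fold higher number from compound 1 to compound 3 (0.72 log units; beyond the scatter), which runs the other way, because compound 4, like compound 1, places a piperidin-1-yl bearing an amide on that carbon. Compound 4 is therefore expected to show a step of a 3.8-fold lower number from compound 3 to compound 4 (0.57 log units; beyond the scatter). The estimate for compound 4 in this assay is 45 nM, in a range from 15 nM to 140 nM.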

Compound 4, half-maximal inhibitory concentration: 11 nM
Compound 4: middle estimate off by 4.1-fold (0.61 log units), on the high side; measured number below the stated range.
By their numbers in this assay, from the lowest: compound 4; then compounds 1 and 2 (each within the scatter of the next); then compound 3.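

In this assay, 4-(2-oxopyrrolidin-1-yl)piperidin-1-yl on this carbon between two ring nitrogen atoms outdoes both methanesulfonamido chains, giving a 15-fold lower number from compound 3 to compound 4 (1.19 log units; beyond the scatter) and a 4.9-fold lower number from compound 2 to compound 4 (0.69 log units; beyond the scatter). With the piperidine kept, 2-oxopyrrolidin-1-yl in place of ((methoxymethyl)carbonyl)amino on the saturated ring carbon gives a 2.9-fold lower number from compound 1 to compound 4 (0.46 log units; beyond the scatter), so the group on that ring also moves the number beyond the scatter. No measurement offered here explains these steps.

The compounds shown leave open how a primary amine or a carboxylic acid on that saturated ring carbon would read.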